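Stilbene-like series: hydroxyphenylethenyl for vinyl on the chain carbon

This account rests on a few compounds, and the source may have more. Where it says the series, first, only, none or still open, it means among the compounds named here.

Measured so far:
- compound 1, `C=C[C@@](C)(/C=C/c1ccc(OC(=O)CCCCC)cc1)CCC=C(C)C`, 19%
- compound 2, `C=C[C@@](C)(/C=C/c1ccc(OC)cc1)CCC=C(C)C`, 30%

For the measured compounds named here, in a functional assay on IMR-32 cells (Homo sapiens) for inhibition, with a stated time of 48 h, tested at 50 uM (a lower number here means less inhibition of growth, a higher number more inhibition of growth at the concentration tested), compound 2 stands highest of the two numbers so far; its nearest neighbour is compound 1, and the step of a number 11 percentage points higher from compound 1 to compound 2 (beyond the scatter) is the only one measured. That step concerns the group on the aromatic oxygen, not the chain carbon, so it does not bear directly on the next change.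

Compound 3, `COc1ccc(/C=C/[C@](C)(/C=C/c2ccc(O)cc2)CCC=C(C)C)cc1`, differs from compound 2 by 2-(4-hydroxyphenyl)ethenyl in place of vinyl on a saturated chain carbon bound to a double-bonded chain carbon and two saturated chain carbons. Going by the values given here, no measured pair shows what replacing vinyl at this place does, so the direction rests on the structural change alone rather than on a measured step.

A modest rise in this assay is expected for compound 3, a number 15 percentage points higher from compound 2 to compound 3 (beyond the scatter), with wide uncertainty. The estimate for compound 3 in this assay is 45%, within 20% to 75%.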

Compound 3, percent growth inhibition at one concentration: 69%
Compound 3: middle estimate off by 24 percentage points, on the low side; the range from low to high includes it.
By their numbers in this assay, from the lowest: compound 1; then compound 2; then compound 3.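

Placing 2-(4-hydroxyphenyl)ethenyl instead of vinyl on the saturated chain carbon bound to a double-bonded chain carbon and two saturated chain carbons gives a number 39 percentage points higher from compound 2 to compound 3 (beyond the scatter) in this assay. This place therefore accepts a much larger group, with an added aromatic ring and hydrogen-bond donor, while growth inhibition rises rather than falls. The step is large, whereas the change on the aromatic oxygen, a number 11 percentage points higher from compound 1 to compound 2 (beyond the scatter), is modest; no measurement bears on the reason for the rise.

Still open, going by these compounds, is whether the gain follows the aromatic ring or its hydroxy group, a question that an amine or a carboxylic acid in place of that hydroxy group would test. Also open, on these data alone, is whether pentylcarbonyl in place of methyl on the aromatic oxygen would lower the number with the larger group present.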